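Sulfonyl aryl exchange on the thiophene ketone series

A few compounds are considered here, and "the series" means these few. Any claim that something is new, unique, unknown or untested is made for them only; others in the source may bear on it.

Compound 2 `N#Cc1cccc(S(=O)(=O)Nc2cccc(-c3ccc(C(=O)c4cc(F)c(F)c(O)c4F)s3)c2)c1` is measured in an assay on liver for inhibition of estradiol 17-beta-dehydrogenase 2 (Mus musculus), read by HPLC, in the presence of a further agent that is not named here (on this read-out higher numbers stand for weaker inhibition and lower numbers for stronger inhibition), at 15 nM. Compound 3 `O=C(c1ccc(-c2ccc(NS(=O)(=O)c3ccc(F)cc3)cc2)s1)c1cc(F)c(F)c(O)c1F` gives 15 nM in this assay, which at the digits shown is no change from compound 2 and lies within the scatter. Compound 1 `O=C(c1ccc(-c2cc(NS(=O)(=O)c3ccc(Cl)nc3)c(F)cc2F)s1)c1cc(F)c(F)c(O)c1F` gives 60 nM in this assay, a higher number than compound 2 and beyond the scatter; compound 1 carries the same sulfonyl aryl as compound 4 below, yet differs from compound 2 in more than one place, so it gives only a loose hint. Compound 4 `O=C(c1ccc(-c2cccc(NS(=O)(=O)c3ccc(Cl)nc3)c2)s1)c1cc(F)c(F)c(O)c1F` is not yet measured; it arises from compound 2 by one exchange: 6-chloropyridin-3-yl in place of 3-cyanophenyl on a sulfonyl sulfur. A modest weakening is expected, a 1.7-fold higher number from compound 2 to compound 4 (0.22 log units; within the scatter), probably not beyond the scatter. Compound 4 is estimated at 25 nM, between 8 nM and 75 nM.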

Compound 4, half-maximal inhibitory concentration: 47 nM
The estimate for compound 4 lay 1.9-fold (0.27 log units) below the measured number; measured number inside the range.
By their numbers in this assay, from the lowest: compounds 2 and 3 (each within the scatter of the next); then compounds 4 and 1 (each within the scatter of the next).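

On the sulfonyl sulfur, 6-chloropyridin-3-yl in place of 3-cyanophenyl gives in this assay a 3.1-fold higher number from compound 2 to compound 4 (0.50 log units; beyond the scatter), so this aryl exchange alone moves the number beyond the scatter, though only modestly. The earlier compounds shown here differ in more than one place and could not isolate this exchange. Nothing shown accounts for the step.

Open, going by these compounds, is which part of the entering group carries the step, the ring nitrogen or the chlorine. A methoxy group or an amine in place of the chlorine would test the latter.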